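Solubility across acylated thione series: compound 4

A few compounds are considered here, and "the series" means these few. Any claim that something is new, unique, unknown or untested is made for them only; others in the source may bear on it.

Measured so far:
- compound 1, `CCCCCCCCCCCCCCCC(=O)n1c(=S)oc2ccccc21`: 63000 nM in a physicochemical assay for solubility; a higher number here means a more soluble compound, a lower number a less soluble compound
- compound 2, `CCCC(=O)n1c(=S)[nH]c2ccccc21`: 190000 nM in this assay
- compound 3, `CCCCCC(=O)n1c(=S)[nH]c2ccccc21`: 170000 nM in this assay

Compound 1 gives the lowest number of the three in this assay; compound 3 stands nearest to it and compound 2 furthest, and both of those gaps lie beyond the scatter. Compound 2 and compound 3 share one core, compound 1 another, so their values are only set side by side here.

Compound 4, `CCCCCCCCCC(=O)n1c(=S)oc2ccccc21`, is not yet measured. It differs from compound 1 by hydrogen in place of hexyl on a saturated chain carbon, nine bonds along the chain from a carbonyl carbon. For the measured compounds named here, the one measured step on a chain carbon is a 1.1-fold lower number from compound 2 to compound 3 (0.05 log units; within the scatter), which is within the scatter and concerns a far smaller change on a different core. Going by the values given here, no measured step covers a shortening of this size on the core of compound 1.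

On the direction of the chain change, the number for compound 4 in this assay is expected to rise, and the step of a 2.5-fold higher number from compound 1 to compound 4 (0.40 log units; beyond the scatter) is the estimated size. The value expected for compound 4 is 160000 nM, within a range from 60000 nM to 420000 nM.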

Compound 4, solubility: 100000 nM
Beside the measured number, compound 4's estimate is 1.6-fold (0.20 log units) above it; the range from low to high includes it.
By their numbers in this assay, from the lowest: compounds 1, 4, 3 and 2 (each within the scatter of the next, the first and the last beyond it).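

In this assay, for the compounds shown here, hydrogen in place of hexyl on a saturated chain carbon, nine bonds along the chain from a carbonyl carbon, gives a 1.6-fold higher number from compound 1 to compound 4 (0.20 log units; within the scatter) and is the first step on the core of compound 1, so a change of this size at this position is not resolved from the scatter on that core. The earlier step, a 1.1-fold lower number from compound 2 to compound 3 (0.05 log units; within the scatter), concerned a much smaller chain change on another core; both chain steps now lie within the scatter, and neither of the two goes against the other, although two steps on two cores make no general rule. Nothing available bears on the reason for this result.

Still open, as far as these compounds go, is whether a terminal amine or carboxylic acid on the chain of compound 4, rather than a change in chain length alone, would give a step beyond the scatter. Also open is how the two cores compare when they carry the same chain, since the compounds shown include no pair that differs only in the core.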